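A few compounds are considered here, and "the series" means these few. Any claim that something is new, unique, unknown or untested is made for them only; others in the source may bear on it.

Measured so far:
Compound 1, `CO[C@H]1O[C@H](COc2ccc(OC3CCCCC3)cc2)[C@@H](O)[C@H](O)[C@H]1Oc1ccc(OC2CCCCC2)cc1`: 18000 nM
Compound 2, `CO[C@@H]1O[C@H](COc2ccc(OC3CCCCC3)cc2)[C@@H](O)[C@H](O)[C@H]1Oc1ccc(C(C)C)cc1`: 32000 nM

Of the compounds shown here, two have been tested in a functional assay on A549 cells (Homo sapiens) for cytotoxicity, read by MTT assay, with a stated time of 48 h; on this read-out lower numbers stand for an effect already at smaller amounts and higher numbers for an effect only at larger amounts of compound. Compound 2 gives the higher of the two numbers, but its gap to compound 1 lies within the scatter, so the two cannot be told apart on these data.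

Compound 3, `CO[C@@H]1O[C@H](COc2ccc(OC3CCCCC3)cc2)[C@@H](O)[C@H](O)[C@H]1Oc1ccc(OC2CCCCC2)cc1`, has not yet been measured. It differs from compound 2 in one place: cyclohexyloxy in place of isopropyl on an aromatic carbon

Among the compounds with values here, no step between two measured compounds shows what such a swap does. The only hint is indirect: compound 1 also carries a cyclohexyloxy group at this position and gives 18000 nM, close to compound 2. The step from compound 2 to compound 3 is therefore expected to be small, a 1.6-fold lower number from compound 2 to compound 3 (0.20 log units; within the scatter), not beyond the scatter. For compound 3 the estimated result in this assay is 20000 nM, with a likely range from 8000 nM to 50000 nM.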

Compound 3, half-maximal effective concentration: 25000 nM
The estimate for compound 3 lay 1.3-fold (0.10 log units) below the measured number, and the stated range covers the measured number.
By their numbers in this assay, from the lowest: compounds 1, 3 and 2 (each within the scatter of the next).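

In this assay, cyclohexyloxy in place of isopropyl on the aromatic carbon gives a 1.3-fold lower number from compound 2 to compound 3 (0.11 log units; within the scatter). This first direct view of the swap therefore shows no effect that can be told from the scatter, even though the entering group brings a six-membered ring and a hydrogen-bond acceptor that isopropyl lacks. Inverting the drawn configuration at one saturated ring carbon gives a 1.4-fold higher number from compound 1 to compound 3 (0.14 log units; within the scatter), so this stereocentre also shows no readable effect, and the comparison tests that single feature: the fact that compounds 1 and 3 differ only in the configuration as drawn

Neither step says whether a different kind of group on this aromatic carbon, such as an amine or a carboxylic acid, would shift the number beyond the scatter. Going by these compounds, it also remains open whether isopropyl would give a similar number with the stereocentre drawn as in compound 1.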